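A few compounds are considered here, and "the series" means these few. Any claim that something is new, unique, unknown or untested is made for them only; others in the source may bear on it.

Four compounds are compared here, all sharing a core that carries an ester, a five-membered ring and a six-membered aromatic ring. Compound 1 `COC(=O)c1nc(-c2ccoc2)n(-c2ccc(F)cc2)n1` and compound 2 `COC(=O)c1nc(-c2ccoc2)n(-c2ccc(C(F)(F)F)cc2)n1` differ in one place only, by fluoro in place of trifluoromethyl on an aromatic carbon. In a functional assay on Jurkat cells (Homo sapiens) for inhibition, read by MTT assay, with a stated time of 72 h (on this read-out higher numbers stand for weaker inhibition of growth and lower numbers for stronger inhibition of growth), compound 2 gives 97200 nM. In this assay compound 1 gives 9320 nM. That single change therefore made a 10-fold lower number from compound 2 to compound 1 (1.02 log units; beyond the scatter).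

Compound 3 `CCOC(=O)c1nc(-c2ccc[nH]2)n(-c2ccc(C(F)(F)F)cc2)n1` has a different core, and how its core differs from that of compound 2 is not broken down here. In this assay compound 3 gives only > 100000 nM, which is a limit of the assay rather than a number, the same limit as the limit of > 100000 nM in this assay, at which 1 of the 3 values shown sits.

Compound 4 `CCOC(=O)c1nc(-c2ccc[nH]2)n(-c2ccc(F)cc2)n1` has not yet been measured in this assay. It stands to compound 3 exactly as compound 1 stands to compound 2: it differs by fluoro in place of trifluoromethyl on an aromatic carbon, the same change at the same place. Because compound 3 gives only > 100000 nM the starting point of the new step is not fixed. For compound 4 a step of an at least 2.8-fold lower number from compound 3 to compound 4 (0.45 log units; beyond the scatter) is expected, resting on the earlier step of a 10-fold lower number from compound 2 to compound 1 (1.02 log units; beyond the scatter) seen from compound 2 to compound 1. Compound 4 is therefore estimated to give 35000 nM in this assay. For compound 4 the expected range runs from 10000 nM to 150000 nM.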

Compound 4, concentration for 50% growth inhibition: > 100000 nM
Compound 4: no number, only a limit; the forecaster's own chance of this, stated with the estimate: 35%; middle value at least 2.8-fold (0.45 log units) from the limit.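

In this assay compound 4 gives > 100000 nM, which is a limit of the assay and not a number. Compound 3 sits at the same limit, so the step between compound 3 and compound 4 cannot be read: the limit of > 100000 nM in this assay, at which 2 of the 4 values shown sit.

The compounds shown leave open whether fluoro in place of trifluoromethyl changes growth inhibition at all on the core of compound 3.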